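The source may hold more compounds than are shown below. What is called first, only, known or untested is meant among the compounds shown, and "the series" means these compounds.

The study concerns a set of compounds that share one core and were examined in an assay on isolated protein for inhibition of polyamine deacetylase HDAC10 (Homo sapiens); on this read-out lower numbers stand for stronger inhibition and higher numbers for weaker inhibition. Compound 1 `COc1cc(C(=O)c2ccc3c(ccn3S(=O)(=O)c3ccc(/C=C/C(=O)NO)cc3)c2)cc(OC)c1OC` gives only a limit in this assay, > 100000 nM, so no number is known for it. That value sits at the limit of > 100000 nM in this assay, at which 1 of the 3 values shown sits. Compound 2 `COc1ccc(C(=O)c2ccc3c(ccn3Cc3ccc(C(=O)NO)cc3)c2)cc1OC` gives 18900 nM in this assay. Compound 3 `COc1cccc(C(=O)c2ccc3c(ccn3S(=O)(=O)c3cccc(/C=C/C(=O)NO)c3)c2)c1` gives 7740 nM in this assay, which is the lowest of the two numbers measured; the nearest is compound 2, whose number is higher by a gap that lies beyond the usual scatter of repeated measurements.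

Compound 4 `Cc1ccc(C(=O)c2ccc3c(ccn3S(=O)(=O)c3cccc(/C=C/C(=O)NO)c3)c2)cc1` has not been measured. It differs from compound 3 in a single place: 4-methylphenyl in place of 3-methoxyphenyl on a carbonyl carbon. Going by the values given here, no pair of measured compounds differs in only this one place, so there is no measured step to lean on for this change. The step is expected to stay within the usual scatter, with no clear direction, a 1.0-fold higher number from compound 3 to compound 4 (0.01 log units; within the scatter). Compound 4 is therefore estimated to give 8000 nM in this assay, in a range from 2500 nM to 25000 nM.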

Compound 4, half-maximal inhibitory concentration: 9100 nM
Beside the measured number, compound 4's estimate is 1.1-fold (0.06 log units) below it; the measured number falls inside the stated range.
By their numbers in this assay, from the lowest: compounds 3 and 4 (each within the scatter of the next); then compound 2. At a limit, above all of these: compound 1.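

In this assay, going by these compounds alone, the exchange of 4-methylphenyl for 3-methoxyphenyl on a carbonyl carbon gives the first step that can be read at this position: a 1.2-fold higher number from compound 3 to compound 4 (0.07 log units; within the scatter). The two compounds cannot be told apart here, although 3-methoxyphenyl has 1 hydrogen-bond acceptor and 4-methylphenyl has 0, so at this level of inhibition, this acceptor count makes no difference that the numbers can resolve for this one pair. The information at hand does not bear on this step and offers no explanation for it.

A single pair also leaves unresolved whether the identity of the group or its place on the phenyl ring matters, since both differ at once in this exchange. Going by these compounds, whether an amine or a carboxylic acid on that phenyl ring, or a longer chain in place of the methyl group, would give a number beyond the scatter from that of compound 3 also remains open.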